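This account rests on a few compounds, and the source may have more. Where it says the series, first, only, none or still open, it means among the compounds named here.

Compound 3 `CNC(=O)N[C@H]1CCN(c2cccc3c2CCO3)C1` carries a methyl urea on one face of the shared core and gives the lowest number of the three measured in an assay on NIH3T3 cells for binding affinity to melatonin receptor type 1A (Homo sapiens) (a lower number here means a stronger inhibitor, a higher number a weaker inhibitor), namely 0.9 nM. Compound 1 `CCCNC(=O)N[C@@H]1CCN(c2cccc3c2CCO3)C1`, with a propyl group in place of the methyl and the opposite drawn configuration, gives 4.4 nM, and compound 2 `O=C(NC1CC1)N[C@@H]1CCN(c2cccc3c2CCO3)C1`, with a cyclopropyl group, gives 6.6 nM; the step of a 1.5-fold higher number from compound 1 to compound 2 (0.18 log units; within the scatter) shows that exchanging these two groups changes little. Compound 4 `CNC(=O)N[C@@H]1CCN(c2cccc3c2CCO3)C1` is the mirror form of compound 3 at the ring carbon: the two compounds have the same atoms and bonds and differ only in configuration as drawn: 1 of 1 stereo elements differ; a stereocentre at a saturated ring carbon is drawn S in compound 3 and R in compound 4. For the measured compounds named here, no measured step isolates a change in configuration alone, so the expectation rests on the weaker showing of compounds 1 and 2, which share the drawn configuration of compound 4 but differ in the urea group as well. The step of an 11-fold higher number from compound 3 to compound 4 (1.05 log units; beyond the scatter) is therefore expected to be a rise beyond the scatter, though its size is uncertain. Compound 4 is estimated at 10 nM, within 1.5 nM to 60 nM in this assay.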

Compound 4, inhibition constant: 2.2 nM
Compound 4: the middle estimate sits 4.5-fold (0.66 log units) above what was measured; the range from low to high includes it.
By their numbers in this assay, from the lowest: compound 3; then compounds 4, 1 and 2 (each within the scatter of the next, the first and the last beyond it).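

In this assay, the drawn configuration at this saturated ring carbon can now be read directly, as a modest step of a 2.4-fold higher number from compound 3 to compound 4 (0.39 log units; beyond the scatter), and it can be put down to that configuration alone because nothing else changes: the fact that compounds 3 and 4 differ only in the configuration as drawn. With the R configuration held fixed, the group on the urea can also be read on its own: methyl in place of cyclopropyl gives a 3.0-fold lower number from compound 2 to compound 4 (0.48 log units; beyond the scatter), and hydrogen in place of ethyl on the chain, which turns propyl into methyl, gives a 2.0-fold lower number from compound 1 to compound 4 (0.30 log units; within the scatter). Configuration alone thus covers only part of the distance from compound 3 to compounds 1 and 2.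

From the compounds shown here alone, it remains open whether the S configuration would give a similar step with a propyl or cyclopropyl group on the urea. Going by these compounds, how an ethyl group or a longer chain such as butyl would read on either configuration also stays open.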